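This account rests on a few compounds, and the source may have more. Where it says the series, first, only, none or still open, it means among the compounds named here.

Compound 3 `CCc1ccc(-c2cn3ccnc3c(-c3ccc4ncn(Cc5ccccc5)c4c3)n2)cc1` gives 35.1% in a functional assay on OVCAR-4 cells (Homo sapiens) for inhibition, read by sulforhodamine B assay, with a stated time of 48 h, tested at 10 uM (on this read-out higher numbers stand for more inhibition at the one concentration tested (going by the name of the read-out) and lower numbers for less inhibition), the highest of the three numbers measured. Compound 1 `Brc1cn2ccnc2c(-c2ccc3ncn(C4CCCCC4)c3c2)n1` gives 9.15%, and compound 2 `Clc1ccc(-c2cn3ccnc3c(-c3ccc4ncn(C5CCCCC5)c4c3)n2)cc1` gives 4.57%; both sit beyond the scatter below compound 3. Compound 4 `Cc1cccc(-c2cn3ccnc3c(-c3ccc4ncn(Cc5ccccc5)c4c3)n2)c1` has not yet been tested, and it differs from compound 3 in one place: 3-methylphenyl in place of 4-ethylphenyl on an aromatic carbon. Among the compounds with values here, the only measured step, a number 4.6 percentage points lower from compound 1 to compound 2 (within the scatter), concerns a different kind of exchange, so it offers no direct guide to this change. With the rest of the structure kept, the step of a number 7.1 percentage points lower from compound 3 to compound 4 (within the scatter) is expected to be small, with no direction beyond the scatter. For compound 4 the estimated value is 28%, with a range from 8% to 48%.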

Compound 4, a percentage reported as inhibition, at one concentration (the size of the read-out at that concentration, not a potency): 19.3%
The estimate for compound 4 lay 8.7 percentage points above the measured number; low and high end bracket the measured number.
By their numbers in this assay, from the lowest: compounds 2 and 1 (each within the scatter of the next); then compound 4; then compound 3.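

The step of a number 15.8 percentage points lower from compound 3 to compound 4 (beyond the scatter) in this assay shows that this position can respond to a small change on the phenyl group, which the earlier step from bromo to 4-chlorophenyl did not show. The exchange alters both the chain and its place on the ring, so the step cannot be assigned to either change alone. Nothing available explains the drop.

The compounds shown leave open which of the two changes matters more. They also leave open how an amine or a carboxylic acid on this phenyl ring would read out.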